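The compounds below may be only part of what the source reports. "The series", "measured", "known", "first", "only" and "open" are said of these compounds alone.

Of the compounds shown here, three of one series have been measured so far in an ADME assay on L6 cells (Rattus norvegicus) for cytotoxicity, read by resazurin assay, with a stated time of 70 h; a higher number here means a weaker inhibitor, a lower number a stronger inhibitor. Compound 1, `c1ccc(OCCCOc2cccc(-c3cc4ccc(C5=NCCN5)cc4o3)c2)cc1`, gives 10100 nM; compound 2, `CC(C)NC(=N)c1ccc2cc(-c3cccc(OCCCCCOc4ccccc4)c3)oc2c1`, gives 20100 nM; compound 3, `N=C(N)c1ccc2cc(-c3ccc(OCCCOc4ccccc4)cc3)oc2c1`, gives 8600 nM. Among these three numbers, compound 3 stands at the low end: the number of compound 1 sits within the usual scatter of it, so the two cannot be told apart, whereas the number of compound 2 lies beyond that scatter.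

The step now followed leads from compound 3 to compound 4, `CC(C)NC(=N)c1ccc2cc(-c3ccc(OCCCOc4ccccc4)cc3)oc2c1`. Between them the only change is isopropyl in place of hydrogen on an amine nitrogen, that is, the amino group becomes an isopropylamino group. Among the measured compounds shown here, no pair of compounds already measured differs in just this place, so the size of the step is open. Compound 2 carries the same isopropylamino group and gives 20100 nM, but it also bears a longer chain in the linker, so that number is only a loose pointer. For this assay , a small rise in the number is expected, with a 1.5-fold higher number from compound 3 to compound 4 (0.18 log units; within the scatter) as the estimated step. Compound 4 is therefore expected to come out near 13000 nM, within a range from 6000 nM to 30000 nM.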

Compound 4, half-maximal inhibitory concentration: 49900 nM
The estimate for compound 4 lay 3.8-fold (0.58 log units) below the measured number; measured number above the stated range.
By their numbers in this assay, from the lowest: compounds 3, 1 and 2 (each within the scatter of the next, the first and the last beyond it); then compound 4.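

In this assay, among the compounds shown here, isopropyl in place of hydrogen on an amine nitrogen gives a 5.8-fold higher number from compound 3 to compound 4 (0.76 log units; beyond the scatter), and this is the first single change whose size can be read. The step lies beyond the scatter, so this nitrogen, whose other neighbour is a carbon with a double bond to nitrogen, does not tolerate the change from amino to isopropylamino without a shift in the number. Nothing measured here accounts for the size of this step.

The compounds shown leave open whether a methyl or a cyclopentyl group on this nitrogen would give a step of similar size. They also leave open whether the change from amino to isopropylamino gives the same step on a compound with a longer chain in the linker.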